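This account rests on a few compounds, and the source may have more. Where it says the series, first, only, none or still open, it means among the compounds named here.

Compound 1 `COc1cccc(CNC(=O)c2nc(Br)c3cccnc3c2N[C@H]2CC[C@H](N)CC2)c1` is one of three compounds from this series characterised in a functional assay on MDA-MB-435 cells (Homo sapiens) for cytotoxicity, read by MTT assay, with a stated time of 72 h; on this read-out higher numbers stand for weaker inhibition and lower numbers for stronger inhibition. In this assay compound 1 gives 7000 nM. Its closest companion is compound 2 `N[C@H]1CC[C@H](Nc2c(C(=O)NCc3ccc(F)cc3)nc(N3CCCCC3)c3cccnc23)CC1`, which in this assay gives 5000 nM; the two numbers lie within the scatter of each other, so neither can be set above the other. Compound 3 `C[C@H](CO)Nc1nc(C(=O)NCc2ccc(F)cc2)c(O)c2ncccc12` is different: in this assay compound 3 reaches only a limit of the assay, reported as > 20000 nM, and that limit is recorded as the limit of > 20000 nM in this assay, at which 1 of the 3 values shown sits. Compound 1 therefore stands alongside compound 2 among the numbers actually measured, with compound 3 sitting at the limit.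

The step now followed leads from compound 1 to compound 4 `N[C@H]1CC[C@H](Nc2c(C(=O)NC3CCCCC3)nc(Br)c3cccnc23)CC1`, not yet measured in this assay. The change is cyclohexyl in place of 3-methoxybenzyl on an amide-type nitrogen.

Among the measured compounds shown here, no measured pair in this set differs in one place, so the size of this step cannot be read from neighbouring compounds. On what the structures show, the expectation is a modest loss of potency: the estimated step of a 2.0-fold higher number from compound 1 to compound 4 (0.30 log units; within the scatter) is expected to run toward a higher number, somewhat beyond the scatter. Compound 4 is accordingly expected to give about 14000 nM in this assay, within a range from 5000 nM to 40000 nM.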

Compound 4, half-maximal inhibitory concentration: > 10000 nM
Compound 4: no number, only a limit (the forecaster's own chance of this, stated with the estimate: 30%); the middle value lies beyond the limit too.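

In this assay compound 4 gives > 10000 nM, which is a limit of the assay and not a number. Cyclohexyl in place of 3-methoxybenzyl on the amide-type nitrogen gives the first comparison in this set that differs in one place, and it can be stated only as a floor: an at least 1.4-fold higher number from compound 1 to compound 4 (0.15 log units; that floor lies within the scatter). The result shows that replacing the aromatic ring of the 3-methoxybenzyl group with the non-aromatic ring of cyclohexyl gives no measured number below that of the starting compound, but the floor is within the scatter, so it does not establish a real loss or show how large any loss might be.

The compounds shown leave open how far the true value of compound 4 lies past the limit, and whether the aromatic ring or the methoxy oxygen is the part of the group that counts. An unsubstituted benzyl on the same nitrogen, or a short chain ending in an amine, would test these two parts separately against the shared core.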